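From 4-methylpiperazin-1-yl to (piperidin-3-yl)amino on a carbonyl carbon

The source may report more compounds than this note shows. Statements on the series, on what has been measured and on what is new or still open speak of the compounds shown alone.

In a functional assay on EBC-1 cells (Homo sapiens) for antiproliferative activity, with a stated time of 72 h (a higher number here means a weaker inhibitor, a lower number a stronger inhibitor), compound 3 `CN1CCN(C(=O)c2ccc(-c3cc(F)c4ncc(Cc5ccc6ncccc6c5)n4c3)cc2F)CC1` gives 869 nM and compound 2 `CCO/N=C(\C)c1cc(F)c2ncc(Cc3ccc4ncccc4c3)n2c1` gives 1480 nM. This gap lies within the usual scatter, so compound 3 stands level with compound 2. For compound 1 `Cn1cc(-c2cc(C#N)c3ncc(Cc4ccc5ncccc5c4)n3c2)cn1` the entry reads "not determined" (no result reported). Compound 4 `O=C(NC1CCCNC1)c1ccc(-c2cc(F)c3ncc(Cc4ccc5ncccc5c4)n3c2)cc1F` carries (piperidin-3-yl)amino in place of 4-methylpiperazin-1-yl on a carbonyl carbon. Going by the values given here, no measured pair isolates that change, so the expectation rests on compound 3 alone, and no shift beyond the scatter is expected in this assay. The expected step is a 1.2-fold lower number from compound 3 to compound 4 (0.09 log units; within the scatter). Compound 4 is estimated at 700 nM, with an expected range of 220 nM to 2200 nM.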

Compound 4, half-maximal inhibitory concentration: 138 nM
Estimate against measurement, compound 4: 5.1-fold (0.71 log units) above; the whole stated range lies above it.
By their numbers in this assay, from the lowest: compound 4; then compounds 3 and 2 (each within the scatter of the next).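

In this assay the group on this carbonyl carbon proves to matter: (piperidin-3-yl)amino in place of 4-methylpiperazin-1-yl gives a 6.3-fold lower number from compound 3 to compound 4 (0.80 log units; beyond the scatter) with the heavy-atom count unchanged. Going by these compounds alone, this is the first step beyond the scatter, and it rests on this one pair. Nothing at hand explains the difference.

Still open, going by these compounds, is whether the amide hydrogen or the piperidine ring carries the step. A (1-methylpiperidin-3-yl)amino group or an open-chain (2-aminoethyl)amino group on the same carbonyl carbon would separate the two.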